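The source may report more compounds than this note shows. Statements on the series, on what has been measured and on what is new or still open speak of the compounds shown alone.

Of the compounds shown here, two have so far been measured in a functional assay on the whole organism (strain Wistar) for inhibition, with Rattus norvegicus as the target, read by paw edema, with stated times of 30 min and 5 h, at a dose of 0.05 mmol/kg by the oral route; on this read-out lower numbers stand for less inhibition and higher numbers for more inhibition at the one dose given (going by the name of the read-out). Compound 1 `Cc1ccc(C2=NN(c3ccc(S(C)(=O)=O)cc3)C(=O)CC2)cc1` gives 60.5%. Compound 2 `CS(=O)(=O)c1ccc(N2N=C(c3ccc(-c4ccccc4)cc3)CCC2=O)cc1` gives 21%. Among the measured compounds shown here, compound 2 stands lowest of the two numbers; its nearest neighbour is compound 1, and the only step recorded between them is a number 39.5 percentage points lower from compound 1 to compound 2 (beyond the scatter), which is large and beyond the scatter.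

Compound 3 `CS(=O)(=O)c1ccc(N2N=C(c3ccc(F)cc3)CCC2=O)cc1` is not yet measured in this assay . Its change from compound 2 is fluoro in place of phenyl on an aromatic carbon. For the measured compounds named here, the one measured step bears on this change in reverse: the phenyl that entered on the way from compound 1 to compound 2 now leaves again, and a single fluorine atom takes its place, much as a methyl sat in compound 1. Since the step of a number 39.5 percentage points lower from compound 1 to compound 2 (beyond the scatter) was large and downward, a large step upward is expected here, though fluoro is not methyl and a full return to the number of compound 1 is not assured. For compound 3 the expected step is therefore a number 29 percentage points higher from compound 2 to compound 3 (beyond the scatter). Compound 3 is estimated at 50%, with a range from 30% to 70%.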

Compound 3, a percentage reported as inhibition, in the whole organism at one dose (the size of the read-out at that dose, not a potency): 73.6%
Compound 3: middle estimate off by 23.6 percentage points, on the low side, outside the stated range (above it).
By their numbers in this assay, from the lowest: compound 2; then compound 1; then compound 3.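

In this assay, the aromatic carbon para to a large group has now carried phenyl, methyl and fluoro, and the exchange of phenyl for fluoro gives a number 52.6 percentage points higher from compound 2 to compound 3 (beyond the scatter). Methyl does not mark the top of what this position allows, since the change from methyl to fluoro gives a number 13.1 percentage points higher from compound 1 to compound 3 (beyond the scatter); the earlier compounds showed only that phenyl stood well under methyl, whereas the order from the lowest number is now phenyl, methyl, fluoro. Among these three groups the number rises as the group on this carbon changes from phenyl to methyl to fluoro, but three groups do not establish a trend, and no measurement here accounts for the steps.

The compounds shown leave open how chloro, methoxy, an amine or a carboxylic acid on the same carbon would read, and so whether the high number of compound 3 is particular to fluoro or shared with other small groups. From the compounds shown here alone, each number is also a reading at a single dose, which leaves the dose response of all three compounds open, and the rest of the core stays unchanged throughout, so it is open whether the order of these groups holds with any other change to it.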